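The source may hold more compounds than are shown below. What is called first, only, known or untested is meant among the compounds shown, and "the series" means these compounds.

In a functional assay on A549 cells (Homo sapiens) for antiproliferative activity, read by MTT assay, with a stated time of 48 h (on this read-out lower numbers stand for stronger inhibition of growth and higher numbers for weaker inhibition of growth), compound 2 (`COC(=O)N1N=C(c2ccc(OC)cc2)CC1c1cc(OC)c(OC)c(OC)c1`) gives 3400 nM. Compound 3 (`CCCOC(=O)N1N=C(c2ccc(OC)cc2)CC1c1cc(OC)c(OC)c(OC)c1`) gives > 10000 nM, which is a limit and not a number. Compound 1 (`COc1cc(C2CC(c3ccccc3)=NN2C(=O)OCc2ccccc2)cc(OC)c1OC`), which also bears benzyloxycarbonyl, gives > 10000 nM, likewise a limit. That makes the limit of > 10000 nM in this assay, at which 2 of the 3 values shown sit, the place where compound 3 stands. Compound 4 (`COc1ccc(C2=NN(C(=O)OCc3ccccc3)C(c3cc(OC)c(OC)c(OC)c3)C2)cc1`) differs from compound 3 as follows: phenyl in place of ethyl on a saturated chain carbon bound to an oxygen next to a carbonyl group. For the measured compounds named here, only one measured step bears on this change: an at least 2.9-fold higher number from compound 2 to compound 3 (0.46 log units; beyond the scatter), where ethyl replaced hydrogen at the same place. Growth inhibition is therefore expected to stay weak with the larger phenyl. The expected step is a step that the limit leaves unreadable from compound 3 to compound 4, which would not stand beyond the scatter. For compound 4 the estimated value is 12000 nM, with an expected range of 5000 nM to 30000 nM.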

Compound 4, concentration for 50% growth inhibition: > 10000 nM
Compound 4: no number, only a limit (the forecaster's own chance of this, stated with the estimate: 70%); the middle value lies beyond the limit too.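

In this assay, adding phenyl on the saturated chain carbon gives an at least 2.9-fold higher number from compound 2 to compound 4 (0.46 log units; beyond the scatter). Of compounds 2, 3 and 4, only compound 2, with hydrogen at this place, gives a number. The steps from compound 3 and from compound 1 to compound 4 cannot be read because both ends of each are limits: the limit of > 10000 nM in this assay, at which 3 of the 4 values shown sit.

Going by these compounds, how far compound 3 and compound 4 lie past that limit stays open. So does whether a single methyl or an amine at this place would keep growth inhibition measurable.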